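The source may hold more compounds than are shown below. What is called first, only, known or untested is meant among the compounds shown, and "the series" means these compounds.

Working notes on the series. In a functional assay on HCC827 cells (Homo sapiens) for antiproliferative activity, read by sulforhodamine B assay, with a stated time of 72 h (on this read-out lower numbers stand for stronger inhibition and higher numbers for weaker inhibition), compound 3, `Clc1ccc2c(NCCNCc3cn(-c4ccnc5cc(Cl)ccc45)nn3)ccnc2c1`, gives 16000 nM, the lowest of the two numbers recorded so far; its closest neighbour is compound 2, `CN(CCNCc1cn(-c2ccnc3cc(Cl)ccc23)nn1)CCNc1ccnc2cc(Cl)ccc12`, which gives 18000 nM in this assay, a gap within the scatter, so neither is ranked over the other. Compound 1, `CN(CCNCc1cn(CCCO)nn1)CCNc1ccnc2cc(Cl)ccc12`, reaches only a limit of this assay, > 200000 nM, and is not a number. For the measured compounds named here, the one step measured in one place is an at least 11-fold lower number from compound 1 to compound 2 (1.04 log units; beyond the scatter), and it concerns the group on the aromatic nitrogen, not the amine.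

Compound 4, `CN(CCNc1ccnc2cc(Cl)ccc12)Cc1cn(-c2ccnc3cc(Cl)ccc23)nn1`, differs from compound 3 by methyl in place of hydrogen on an amine nitrogen. Going by the values given here, none of the measured steps touches this change: compound 2 carries a methyl on an amine nitrogen too, but it differs from compound 3 in more than one place, so the pair gives no clean reading. Among the compounds with values here, with no measured step to lean on, the expected change in this assay is none beyond the scatter, that is no change at the digits printed from compound 3 to compound 4 (within the scatter). The estimate for compound 4 in this assay is therefore 16000 nM, expected to fall between 6000 nM and 45000 nM.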

Compound 4, half-maximal inhibitory concentration: 18000 nM
Beside the measured number, compound 4's estimate is 1.1-fold (0.05 log units) below it; measured number inside the range.
By their numbers in this assay, from the lowest: compounds 3, 2 and 4 (each within the scatter of the next). At a limit, above all of these: compound 1.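

In this assay, for the compounds shown here, methyl in place of hydrogen on an amine nitrogen gives a 1.1-fold higher number from compound 3 to compound 4 (0.05 log units; within the scatter) and so provides the first reading of a change at this position, since the earlier compounds offered no pair differing only here. At this amine nitrogen, whose other neighbours are saturated chain carbon and saturated chain carbon, hydrogen and methyl cannot be told apart in this read-out, so the hydrogen is not needed to keep the value in the range of compound 3. Nothing measured here gives a cause for this result or says how the methyl acts at this place.

Going by these compounds, it remains open whether a longer chain such as propyl, an acetyl group or a chain ending in a carboxylic acid on this amine nitrogen would also leave the number within the scatter of compound 3. Also open, on these data alone, is whether the same methyl reads alike when 3-hydroxypropyl stands in place of 7-chloroquinolin-4-yl on the aromatic nitrogen.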